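A few compounds are considered here, and "the series" means these few. Any claim that something is new, unique, unknown or untested is made for them only; others in the source may bear on it.

Measured so far in a functional assay on HT-29 cells (Homo sapiens) for cytotoxicity, read by MTT assay, with a stated time of 72 h; on this read-out higher numbers stand for weaker inhibition and lower numbers for stronger inhibition:

- Compound 1, `COc1cccc(/C=C/C(=O)Nc2cc(C(=O)c3cc(OC)c(OC)c(OC)c3)ccc2OC)c1`: 1900 nM
- Compound 2, `COc1ccc(/C=C/C(=O)Nc2cc(C(=O)c3cc(OC)c(OC)c(OC)c3)cc(OC)c2OC)cc1OC`: 2300 nM

On these two numbers compound 2 and compound 1 cannot be told apart: the gap between them is within the scatter of this assay, so neither stands out. Within the data shown here, no single-point step between measured compounds is available in this pair. Compound 1 and compound 2 differ in more than one place.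

Compound 3, `COc1ccc(/C=C/C(=O)Nc2cc(C(=O)c3cc(OC)c(OC)c(OC)c3)cc(OC)c2OC)cc1N`, is the next analogue to be measured. It differs from compound 2 by amino in place of methoxy on an aromatic carbon; the methoxy group that stays in place and the large group on the same ring are kept.

With no measured step of this kind in the series, the expectation rests on the two values alone. The change swaps one small group for another of similar size and count at the same position, so compound 3 is expected to stay close to compound 2, with at most a small drift downward that would not clearly exceed the scatter. The estimated step from compound 2 to compound 3 is a 1.5-fold lower number from compound 2 to compound 3 (0.19 log units; within the scatter). Compound 3 is therefore estimated at 1500 nM in this assay, with a range from 500 nM to 5000 nM.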

Compound 3, half-maximal inhibitory concentration: 7700 nM
Estimate against measurement, compound 3: 5.1-fold (0.71 log units) below, outside the stated range (above it).
By their numbers in this assay, from the lowest: compounds 1 and 2 (each within the scatter of the next); then compound 3.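

In this assay the series gains its first step at a single place: going from 3,4-dimethoxyphenyl to 3-amino-4-methoxyphenyl gives a 3.3-fold higher number from compound 2 to compound 3 (0.52 log units; beyond the scatter) and is modest in size. The position ortho to the methoxy group that stays and meta to the large group is therefore not silent, and exchanging methoxy for amino there moves the number towards weaker inhibition. The change also brings in a hydrogen-bond donor, but a single pair cannot tie the step to that donor, and it sets no rule for the rest of the series.

Open, on these data alone, is whether the step comes from losing the methoxy or from the arrival of the amino itself: a hydroxyl, a methyl, a fluorine or an acetamide at this position would separate those two readings, and the same exchange elsewhere on the shared core is equally unresolved. No measurement at hand bears on what lies behind this step.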